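Ester series: nitro to methyl swap on the benzoate

The source may report more compounds than this note shows. Statements on the series, on what has been measured and on what is new or still open speak of the compounds shown alone.

Three esters have numbers in a functional assay on SK-LU-1 cells (Homo sapiens) for antiproliferative activity, read by sulforhodamine B assay, with a stated time of 48 h, tested at 50 uM; a lower number here means less inhibition, a higher number more inhibition at the concentration tested (going by the name of the read-out). Compound 1 `CC1=CC[C@H](C(C)C)c2cc(C)c(OC(=O)c3ccc([N+](=O)[O-])cc3)cc21` stands highest of the three, giving 47.5% in this assay. Compound 2 `Cc1cc2c(C(C)C)ccc(C)c2cc1OC(=O)c1ccc(C(F)(F)F)cc1` gives 28.7% and compound 3 `COc1cccc(C(=O)Oc2cc3c(C)ccc(C(C)C)c3cc2C)c1` gives 30.6%, both beyond the scatter below compound 1. Among the compounds with values here, no pair of these differs in one place, so no single step is known. Compound 4 `CC1=CC[C@H](C(C)C)c2cc(C)c(OC(=O)c3cccc(C)c3)cc21` keeps the core of compound 1 and differs as 3-methylphenyl in place of 4-nitrophenyl on a carbonyl carbon. Within the data shown here, with no comparable step to lean on, a modest fall is expected, since compound 3 carrying a methoxyphenyl on its ester gives only 30.6%. Compound 4 is estimated at 35%, within 20% to 50%, an expected step of a number 12.5 percentage points lower from compound 1 to compound 4 (beyond the scatter).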

Compound 4, a percentage reported as inhibition, at one concentration (the size of the read-out at that concentration, not a potency): "not active" (no number reported)
For compound 4 the study gives words and no number; no gap can be computed for the estimate.
By their numbers in this assay, from the lowest: compounds 2 and 3 (each within the scatter of the next); then compound 1.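

Within the data shown here, compound 4 is reported in words only, as not active, so no step from compound 1 to compound 4 can be read. No measured evidence bears on this result. The compounds shown leave open how the 4-nitrophenyl on the core of compound 1 contributes to its inhibition.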